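One Inverted Stereocentre and a Solubility Question

This account rests on a few compounds, and the source may have more. Where it says the series, first, only, none or still open, it means among the compounds named here.

Compound 1 `CC[C@@H](C)n1ncn(-c2ccc(N3CCN(c4ccc(OC[C@@H]5CO[C@](C)(c6ccc(Cl)cc6Cl)O5)cc4)CC3)cc2)c1=O`: 800 nM
Compound 2 `C[C@@]1(c2ccc(Cl)cc2Cl)OC[C@@H](COc2ccc(N3CCN(c4ccc(NC(=O)c5cccnc5)cc4)CC3)cc2)O1`: 4.2 nM

In a physicochemical assay for solubility, read by HPLC, in phosphate buffer, measured as kinetic solubility, at pH 7.4 (a lower number here means a less soluble compound, a higher number a more soluble compound), compound 2 gives 4.2 nM, the lower of the two numbers, while compound 1 gives 800 nM, a gap well beyond the scatter. Compound 3 `C[C@]1(c2ccc(Cl)cc2Cl)OC[C@@H](COc2ccc(N3CCN(c4ccc(NC(=O)c5cccnc5)cc4)CC3)cc2)O1` has not yet been measured. It differs from compound 2 in one way: the two compounds have the same atoms and bonds and differ only in configuration as drawn: 1 of 2 stereo elements differ; a stereocentre at a saturated ring carbon is drawn R in compound 2 and S in compound 3. Among the compounds with values here, no measured pair here shows what such a change does. With no guide, only a small shift is expected, if any: the expected step is a 1.4-fold higher number from compound 2 to compound 3 (0.15 log units; within the scatter), within the scatter. Compound 3 is expected to give 6 nM, between 2 nM and 20 nM.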

Compound 3, solubility: 6.9 nM
Beside the measured number, compound 3's estimate is 1.2-fold (0.06 log units) below it; the range from low to high includes it.
By their numbers in this assay, from the lowest: compounds 2 and 3 (each within the scatter of the next); then compound 1.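

In this assay, inverting the stereocentre at the saturated ring carbon gives a 1.6-fold higher number from compound 2 to compound 3 (0.22 log units; within the scatter), so at this position the drawn configuration shifts the reading by no more than repeat measurements would. The comparison is a clean one, with nothing else altered: the fact that compounds 2 and 3 differ only in the configuration as drawn The exchange of aromatic ring groups on the aromatic carbon remains far larger with this configuration, at a 120-fold lower number from compound 1 to compound 3 (2.06 log units; beyond the scatter).

Going by these compounds, what happens on inverting the other stereocentre remains open. So does whether an amine or a carboxylic acid on that aromatic carbon would give a reading closer to that of compound 1.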